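A few compounds are considered here, and "the series" means these few. Any claim that something is new, unique, unknown or untested is made for them only; others in the source may bear on it.

Three compounds have been measured in an assay on isolated protein for inhibition of aldehyde dehydrogenase 1A1 (Homo sapiens), read by spectrophotometry, tested at 10 uM; a higher number here means more inhibition at the concentration tested (going by the name of the read-out), a lower number less inhibition:

Compound 1, `CC(=O)N1CCN(Cc2nc3ccccc3n2Cc2cccc(C)c2)CC1`: 70.3%
Compound 2, `Cc1cccc(Cn2c(CN3CCN(C(=O)c4ccc(C(C)C)cc4)CC3)nc3ccccc32)c1`: 67.6%
Compound 3, `Cc1cccc(Cn2c(CN3CCN(C(=O)c4cccs4)CC3)nc3ccccc32)c1`: 60.8%

All three share one core and differ only in the group attached to a carbonyl carbon. Compound 3 has the lowest of the three numbers, but the steps of a number 9.5 percentage points lower from compound 1 to compound 3 (within the scatter) and a number 6.8 percentage points lower from compound 2 to compound 3 (within the scatter) are both within the scatter, so no order among the three can be claimed.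

Compound 4, `Cc1cccc(Cn2c(CN3CCN(C(=O)C(C)C)CC3)nc3ccccc32)c1`, has not yet been measured. The change from compound 3 is isopropyl in place of thiophen-2-yl on a carbonyl carbon, on a carbonyl carbon whose other neighbours are an amide-type nitrogen in a ring. The measured steps that speak to this are the exchanges at the same carbonyl carbon: a number 2.7 percentage points lower from compound 1 to compound 2 (within the scatter), a number 9.5 percentage points lower from compound 1 to compound 3 (within the scatter) and a number 6.8 percentage points lower from compound 2 to compound 3 (within the scatter). None of them moved the reading beyond the scatter, and the new group, an isopropyl with no ring, is closest in kind to the methyl of compound 1, whose value of 70.3% sits at the top of the narrow range seen so far. The step from compound 3 to compound 4 is therefore expected to stay within the scatter, most likely a small rise. Compound 4 is expected to give about 67%, in a range from 52% to 80%. The expected step is a number 6.2 percentage points higher from compound 3 to compound 4 (within the scatter).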

Compound 4, a percentage reported as inhibition, at one concentration (the size of the read-out at that concentration, not a potency): 87.2%
The estimate for compound 4 lay 20.2 percentage points below the measured number; the whole stated range lies below it.
By their numbers in this assay, from the lowest: compounds 3, 2 and 1 (each within the scatter of the next); then compound 4.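

Among compound 1, compound 2 and compound 3, every exchange at this carbonyl carbon stayed within the scatter, so the position seemed indifferent to the group placed there, but isopropyl is the one group here that clearly moves the reading in this assay, with a number 26.4 percentage points higher from compound 3 to compound 4 (beyond the scatter) and a number 19.6 percentage points higher from compound 2 to compound 4 (beyond the scatter). The most telling comparison is a number 16.9 percentage points higher from compound 1 to compound 4 (beyond the scatter): methyl and isopropyl both have no ring, yet they are separated beyond the scatter, so the absence of a ring on the carbonyl carbon does not by itself set the reading. No evidence is at hand on why isopropyl stands apart.

From the compounds shown here alone, it remains open whether a tert-butyl, a cyclopropyl or a longer chain such as butyl on the same carbonyl carbon would read like isopropyl or like methyl, and what an amine in that place would give. Going by these compounds, each number in this assay comes from a single concentration, so how far the difference between these compounds would carry over to potency also remains open.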